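Ring Size at the Amine and Cytotoxicity in L6 Cells

A few compounds are considered here, and "the series" means these few. Any claim that something is new, unique, unknown or untested is made for them only; others in the source may bear on it.

Compound 1 `O/N=C1\CC2(N3CCCC3)CC(c3ccccc3)C1C(c1ccccc1)C2` and compound 2 `O/N=C1\CC2(N3CCCCC3)CC(c3ccccc3)C1C(c1ccccc1)C2` share one core and differ at a single point, described as piperidin-1-yl in place of pyrrolidin-1-yl on a saturated ring carbon. Going by the values given here, in an ADME assay on L6 cells (Rattus norvegicus) for cytotoxicity (on this read-out lower numbers stand for stronger inhibition and higher numbers for weaker inhibition), compound 1 gives 13500 nM, and compound 2 gives 24200 nM; the step of a 1.8-fold higher number from compound 1 to compound 2 (0.25 log units; within the scatter) is the only measured instance of this change. Compound 3 `O/N=C1\CC2(N3CCCC3)CC(c3ccc(Cl)cc3)C1C(c1ccc(Cl)cc1)C2` carries a different core; the difference between the two cores is not broken down here. In this assay compound 3 gives 12700 nM. Compound 4 `O/N=C1\CC2(N3CCCCC3)CC(c3ccc(Cl)cc3)C1C(c1ccc(Cl)cc1)C2` is not yet measured and stands to compound 3 as compound 2 stands to compound 1, through (piperidin-1-yl in place of pyrrolidin-1-yl on a saturated ring carbon). The surroundings are not identical: in compound 1 the ring atom two ring bonds away bears a phenyl group, whereas in compound 3 it bears a 4-chlorophenyl group, so this is the same kind of change rather than the same change. The account expects a step of a 1.7-fold higher number from compound 3 to compound 4 (0.24 log units; within the scatter) in this assay, resting on the earlier step of a 1.8-fold higher number from compound 1 to compound 2 (0.25 log units; within the scatter) as the only comparable case. For compound 4 the estimate is 22000 nM, between 11000 nM and 45000 nM.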

Compound 4, half-maximal inhibitory concentration: 8750 nM
Compound 4: middle estimate off by 2.5-fold (0.40 log units), on the high side; the measured number lies below the stated range.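

In this assay, putting piperidin-1-yl in place of pyrrolidin-1-yl on the core of compound 3 gives a 1.5-fold lower number from compound 3 to compound 4 (0.16 log units; within the scatter), a step that stays within the usual scatter. Set beside the same change on the core of compound 1, this step gives no sign that the two cores respond differently: the same change on two cores in this assay, a 1.8-fold higher number (0.25 log units; within the scatter) from compound 1 to compound 2 and a 1.5-fold lower number (0.16 log units; within the scatter) from compound 3 to compound 4, 2.6-fold (0.42 log units) apart, within the scatter of two such steps. On these two pairs the change does not move the number beyond the scatter on either core, so the apparent difference in direction cannot be read as a real dependence on the core, but two pairs within the scatter neither prove that the ring size has no effect nor show how the change would carry to any other core.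

The compounds shown leave open whether another amine on this saturated ring carbon, such as morpholin-4-yl or an open-chain dimethylamino group, would also stay within the scatter. They also leave open how the same change would behave on a core bearing another aryl group, such as 4-methoxyphenyl, in place of phenyl or 4-chlorophenyl.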